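Sulfanyl for oxy on the shared core of compound 1

The compounds below may be only part of what the source reports. "The series", "measured", "known", "first", "only" and "open" are said of these compounds alone.

Within the data shown here, compound 1 `Nc1cc(N)c2nc(-c3ccccc3)c(Oc3ccc(Cl)c(Cl)c3)nc2c1` gives the higher of the two numbers measured so far in a functional assay on SF-268 cells (Homo sapiens) for inhibition, read by sulforhodamine B assay, with a stated time of 48 h; on this read-out higher numbers stand for weaker inhibition of growth and lower numbers for stronger inhibition of growth: compound 1 gives 17000 nM. Compound 2 `COc1cc(CNc2nc3cc(N)cc(N)c3nc2-c2ccccc2)cc(OC)c1OC` carries a different group at the same position of the core and in this assay compound 2 gives 2950 nM, a lower number than compound 1, with the gap beyond the usual scatter. Compound 3 `Nc1cc(N)c2nc(-c3ccccc3)c(Sc3ccc(Cl)c(Cl)c3)nc2c1` has not been measured. It differs from compound 1 in one place: (3,4-dichlorophenyl)sulfanyl in place of 3,4-dichlorophenoxy on an aromatic carbon. The dichlorinated ring itself is retained; only the linking atom changes. Among the measured compounds shown here, no measured pair shows this exchange, so no direct step is available. With a single linking atom exchanged, the step in this assay is expected to be small, within the scatter or at most a modest move toward stronger inhibition of growth. Compound 3 is therefore expected to give 12000 nM in this assay, with a range from 4000 nM to 35000 nM. This corresponds to an expected step of a 1.4-fold lower number from compound 1 to compound 3 (0.15 log units; within the scatter).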

Compound 3, concentration for 50% growth inhibition: 13800 nM
Compound 3: middle estimate off by 1.2-fold (0.06 log units), on the low side; the measured number falls inside the stated range.
By their numbers in this assay, from the lowest: compound 2; then compounds 3 and 1 (each within the scatter of the next).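

Among these compounds, the first direct step at this position is now available: in this assay, (3,4-dichlorophenyl)sulfanyl in place of 3,4-dichlorophenoxy gives a 1.2-fold lower number from compound 1 to compound 3 (0.09 log units; within the scatter). With the dichlorinated ring retained, oxygen and sulfur as the linking atom cannot be told apart on this read-out, and neither compound 1 nor compound 3 comes close to compound 2 at 2950 nM, which carries a different group at this position. Nothing available explains why the exchange leaves the number within the scatter.

Still open, as far as these compounds go, is whether a different link to the same ring, such as a (3,4-dichlorophenyl)amino or a (3,4-dichlorophenyl)sulfonyl group, would shift the number in this assay. The compounds shown also do not separate the contribution of the link in compound 2 from that of the rest of its group.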